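Nitro in place of chloro on compound 3

A few compounds are considered here, and "the series" means these few. Any claim that something is new, unique, unknown or untested is made for them only; others in the source may bear on it.

Three measured compounds share one core and differ in the aryl group attached to it. In a functional assay on A549 cells (Homo sapiens) for antiproliferative activity, read by MTT assay, with a stated time of 72 h (a lower number here means a stronger inhibitor, a higher number a weaker inhibitor), compound 1 (`COc1cc(-n2cnc3ccc(-c4ccc(C(C)=O)cc4)cc32)cc(OC)c1OC`) gives 2510 nM, compound 2 (`COc1ccc(-c2ccc3ncn(-c4cc(OC)c(OC)c(OC)c4)c3c2)cc1F`) gives 1430 nM and compound 3 (`COc1cc(-n2cnc3ccc(-c4cccc(Cl)c4)cc32)cc(OC)c1OC`) gives 7050 nM. Compound 3 has the highest number of the three, making it the weakest inhibitor in this small set. Both steps that end at it are modest and beyond the scatter: a 2.8-fold higher number from compound 1 to compound 3 (0.45 log units; beyond the scatter) and a 4.9-fold higher number from compound 2 to compound 3 (0.69 log units; beyond the scatter). The remaining step, a 1.8-fold lower number from compound 1 to compound 2 (0.24 log units; within the scatter), stays within the scatter.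

Compound 4 (`COc1cc(-n2cnc3ccc(-c4cccc([N+](=O)[O-])c4)cc32)cc(OC)c1OC`) carries nitro in place of chloro on an aromatic carbon, meta to a large group, so 3-chlorophenyl becomes 3-nitrophenyl: nitro in place of chloro on an aromatic carbon. Going by the values given here, no measured step makes this exact exchange. Among the compounds with values here, the only guide is the size of the aryl changes already seen, and compound 3 lies at the high end of them at 7050 nM. A modest move in either direction is possible, with a slight lean toward a lower number and no firm expectation of a step beyond the scatter. The expected step is a 1.7-fold lower number from compound 3 to compound 4 (0.22 log units; within the scatter). The estimated value for compound 4 is 4200 nM, with an expected range of 1400 nM to 12000 nM.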

Compound 4, half-maximal inhibitory concentration: 5410 nM
Compound 4: middle estimate off by 1.3-fold (0.11 log units), on the low side, and the stated range covers the measured number.
By their numbers in this assay, from the lowest: compounds 2 and 1 (each within the scatter of the next); then compounds 4 and 3 (each within the scatter of the next).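

In this assay, nitro in place of chloro on an aromatic carbon, meta to a large group, leaves the two compounds indistinguishable (a 1.3-fold lower number from compound 3 to compound 4 (0.11 log units; within the scatter)), although nitro has hydrogen-bond acceptors and chloro has none. Going by these compounds alone, at this position, then, the number does not separate these two groups, the first such direct comparison. The 3-nitrophenyl group also shares the standing of the 3-chlorophenyl group relative to the other two aryl groups, with both steps beyond the scatter (a 2.2-fold higher number from compound 1 to compound 4 (0.33 log units; beyond the scatter); a 3.8-fold higher number from compound 2 to compound 4 (0.58 log units; beyond the scatter)), so among these four compounds, 3-chlorophenyl and 3-nitrophenyl sit together above 4-acetylphenyl and 3-fluoro-4-methoxyphenyl.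

No measurement available on these compounds bears on why the two groups give such similar numbers.

Still open, from the compounds shown here alone, is whether an amine or a carboxylic acid on the same carbon would stay with chloro and nitro or move toward compounds 1 and 2. Also open, going by these compounds, is whether a single methoxy or a longer chain there would behave the same way.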